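Phenyl for Isopropyl on the Core-Side Chain Carbon

The source may report more compounds than this note shows. Statements on the series, on what has been measured and on what is new or still open speak of the compounds shown alone.

Compound 2 `COc1ccc(F)cc1CNCCCNc1ccnc2cc(CC(C)C)ccc12` stands in an ADME assay for permeability, using PAMPA, with a stated time of 30 min, at pH 7.4 (on this read-out higher numbers stand for higher permeability and lower numbers for lower permeability), at 23 10^-6 cm/s, level with compound 1. Compound 1 `CC(C)Cc1ccc2c(NCCCNCc3ccco3)ccnc2c1` gives 23 10^-6 cm/s in this assay. Among the measured compounds shown here, the only measured step, no change at the digits printed from compound 1 to compound 2 (within the scatter), shows that exchanging the group on the saturated chain carbon bound to the amine nitrogen left the read-out unchanged within the scatter.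

Compound 3 `COc1ccc(F)cc1CNCCCNc1ccnc2cc(Cc3ccccc3)ccc12` differs from compound 2 by phenyl in place of isopropyl on a saturated chain carbon bound to an aromatic carbon. For the measured compounds named here, no measured step touches this place: the step of no change at the digits printed from compound 1 to compound 2 (within the scatter) lies on the other end of the molecule, so it offers no direct guide, and only the flat behaviour of the pair so far suggests that this read-out tolerates such exchanges without a step beyond the scatter. Compound 3 is therefore expected to show about 20 10^-6 cm/s, with a range from 10 10^-6 cm/s to 40 10^-6 cm/s. The expected step is a 1.2-fold lower number from compound 2 to compound 3 (0.06 log units; within the scatter), that is, none beyond the scatter.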

Compound 3, apparent permeability: 23 10^-6 cm/s
Compound 3: middle estimate off by 1.2-fold (0.06 log units), on the low side, within the range that was stated.
By their numbers in this assay, from the lowest: compounds 1, 2 and 3 (each within the scatter of the next).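

At this place, on a saturated chain carbon bound to an aromatic carbon, phenyl in place of isopropyl (read one bond further out, benzyl in place of isobutyl) gives no change at the digits printed from compound 2 to compound 3 (within the scatter) in this assay. Among the compounds shown here, this is the first measured exchange at this end of the molecule, and it shows that a six-membered aromatic ring of carbon only can stand here with the read-out level, as it was for the exchange at the other end, which gave no change at the digits printed from compound 1 to compound 2 (within the scatter). Nothing measured here bears on why the read-out stays level.

The compounds shown leave open whether a carboxylic acid or an amine at this place would also leave the read-out level. They also leave open whether a longer chain carrying the phenyl would do so.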